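The source may report more compounds than this note shows. Statements on the series, on what has been measured and on what is new or still open speak of the compounds shown alone.

Compound 1 `CCCc1nc(Br)c2c(Br)nnc(O)n12` — in a functional assay for inhibition, with Homo sapiens as the target (a lower number here means a stronger inhibitor, a higher number a weaker inhibitor), compound 1 gives 48000 nM.
Compound 2 `Oc1nncc2c(Br)nc(Cc3ccccc3)n12` — in this assay compound 2 reaches only a limit, > 48000 nM.
Compound 3 `CCCc1nc(Br)c2cnnc(O)n12` — in this assay compound 3 likewise reaches only a limit, > 48000 nM.

Compounds 1 and 3 share a core; how that core differs from the core of compound 2 is not broken down here. Going from compound 1 to compound 3 the change is hydrogen in place of bromo on an aromatic carbon and the step is a number no lower from compound 1 to compound 3 (the limit leaves the size open). The step that the two limits leave unreadable from compound 2 to compound 3 cannot be read because of the limit of > 48000 nM in this assay, at which 2 of the 3 values shown sit.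

Compound 4 `Oc1nncc2cnc(Cc3ccccc3)n12` has not yet been tested in this assay. Its change from compound 2 is hydrogen in place of bromo on an aromatic carbon. Among the measured compounds shown here, this is the same kind of change as the one from compound 1 to compound 3, not the same: there the bromo left a six-membered aromatic ring with 3 nitrogen, ortho to a fused ring and para to a hydroxy group, while here it leaves a five-membered aromatic ring with 2 nitrogen, two ring bonds from the ring atom that bears a group of 7 heavy atoms. The expected step is a step that the limit leaves unreadable from compound 2 to compound 4, resting on compound 2 already sitting at a limit, > 48000 nM. For compound 4 the estimate in this assay is 96000 nM, between 40000 nM and 400000 nM, and most probably again only a limit.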

Compound 4, half-maximal inhibitory concentration: > 48000 nM
Compound 4 was reported as a limit; the forecaster's own chance of this, stated with the estimate: 85%; the middle value lies beyond the limit too.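

Going from compound 2 to compound 4 puts hydrogen in place of bromo, but no step can be read from this pair because both results are limits rather than numbers: the limit of > 48000 nM in this assay, at which 3 of the 4 values shown sit.

The compounds shown leave open how strongly compound 2, compound 3 and compound 4 actually inhibit in this assay, and so how much hydrogen in place of bromo changes inhibition.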